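Changing the Group on the Carbonyl Carbon of Compound 3

The compounds below may be only part of what the source reports. "The series", "measured", "known", "first", "only" and "open" are said of these compounds alone.

In an ADME assay on microsomes from liver (Homo sapiens) for metabolic stability, read by LC-MS, with a stated time of 30 min, tested at 1 uM (a higher number here means that more of the compound is left, a lower number that less of the compound is left), compound 3 (`O=C(NCc1ccc(S(=O)(=O)c2cccc(C(F)(F)F)c2)cc1)c1ccc2nccn2c1`) stands lowest of the three measured compounds at 26%. Compound 2 (`O=C(NCc1ccc(S(=O)(=O)c2cccc(C(F)(F)F)c2)cc1)c1cnc2nccn2c1`) gives 41% and compound 1 (`O=C(NCc1ccc(S(=O)(=O)c2ccccc2)cc1)c1cc2ccncc2s1`) gives 48%, both higher beyond the scatter. Compound 4 (`O=C(NCc1ccc(S(=O)(=O)c2cccc(C(F)(F)F)c2)cc1)c1cc2ccncc2s1`) departs from compound 3 by one change: a group of 9 heavy atoms (7 carbon, 1 nitrogen, 1 sulfur; one five-membered aromatic ring with 1 hetero atom, one six-membered aromatic ring with 1 hetero atom) in place of a group of 9 heavy atoms (7 carbon, 2 nitrogen; one five-membered aromatic ring with 2 hetero atoms, one six-membered aromatic ring with 1 hetero atom), on a carbonyl carbon. Among the measured compounds shown here, the only measured step at this place is a number 15 percentage points lower from compound 2 to compound 3 (beyond the scatter), and it involves a different exchange, so it offers only a rough guide to size. Compound 1 already carries the entering group, without the trifluoromethyl, and gives 48%, which points to a modest rise. The expected step is a number 11 percentage points higher from compound 3 to compound 4 (beyond the scatter). For compound 4 the estimated value is 37%, with an expected range from 22% to 52%.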

Compound 4, percent of the compound remaining: 43%
The estimate for compound 4 lay 6 percentage points below the measured number; measured number inside the range.
By their numbers in this assay, from the lowest: compound 3; then compounds 2, 4 and 1 (each within the scatter of the next).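

In this assay the entering group on the carbonyl carbon gives a number 17 percentage points higher from compound 3 to compound 4 (beyond the scatter) and so lifts the number over the group it replaces. Set against the other group that leaves, it gives a number 2 percentage points higher from compound 2 to compound 4 (within the scatter) and so puts these two groups level. Trifluoromethyl in place of hydrogen on an aromatic carbon, seen here for the first time as a single change, gives a number 5 percentage points lower from compound 1 to compound 4 (within the scatter) and so moves nothing beyond the scatter. Nothing available explains these steps. On these data alone, whether a nitrile or a chlorine on that aromatic carbon would behave the same stays open.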